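The source may hold more compounds than are shown below. What is called first, only, known or untested is meant among the compounds shown, and "the series" means these compounds.

Measured so far in an assay on HEK293 cells for agonist activity at transient receptor potential cation channel subfamily M member 8 (Homo sapiens), read by fluorescence and calcium flux, with a stated time of 15 min; a higher number here means that more compound is needed for the effect, a lower number that less compound is needed:

Compound 1, `Cc1ccc(OCC(=O)N(Cc2cccs2)c2ccccn2)cc1`: 200 nM
Compound 2, `Cc1ccc(OCC(=O)N(Cc2cccs2)C(C)C)cc1`: 70 nM

Compound 2 has the lowest of these two numbers; its nearest neighbour is compound 1, and the step of a 2.9-fold lower number from compound 1 to compound 2 (0.46 log units; beyond the scatter) is modest but beyond the scatter.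

Compound 3, `Cc1ccc(OCC(=O)N(Cc2cccs2)c2ccncc2)cc1`, differs from compound 2 in one place: pyridin-4-yl in place of isopropyl on an amide-type nitrogen. Among the compounds with values here, the only measured step that bears on this change is a 2.9-fold lower number from compound 1 to compound 2 (0.46 log units; beyond the scatter), in which an isopropyl entered in place of a pyridin-2-yl on the same amide-type nitrogen and the number fell. Putting a pyridine ring back onto that nitrogen, now as pyridin-4-yl, is expected to undo roughly that much, so a modestly higher number in this assay is expected, a step of about a 2.6-fold higher number from compound 2 to compound 3 (0.41 log units; beyond the scatter). Within the data shown here, no measured pair shows how pyridin-4-yl compares with pyridin-2-yl, so the range is kept wide. Compound 3 is estimated at 180 nM, with a range from 60 nM to 550 nM.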

Compound 3, half-maximal effective concentration: 52 nM
For compound 3 the middle estimate is 3.5-fold (0.54 log units) above the measured one, outside the stated range (below it).
By their numbers in this assay, from the lowest: compounds 3 and 2 (each within the scatter of the next); then compound 1.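

Swapping pyridin-2-yl for pyridin-4-yl on the amide-type nitrogen in this assay gives a 3.8-fold lower number from compound 1 to compound 3 (0.59 log units; beyond the scatter), so which pyridine isomer sits there matters, not merely whether a pyridine ring is present. Replacing isopropyl with pyridin-4-yl gives a 1.3-fold lower number from compound 2 to compound 3 (0.13 log units; within the scatter), which lies within the scatter, so an aromatic ring on this nitrogen does not by itself raise the number, and among these three groups only pyridin-2-yl stands apart. Nothing available explains why the two pyridine isomers differ.

Still open, as far as these compounds go, is where pyridin-3-yl or a plain phenyl ring would fall on this nitrogen, which would help show whether the ring nitrogen's location is what counts. Also open, from the compounds shown here alone, is whether a longer chain, such as n-butyl, would match isopropyl.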